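The source may report more compounds than this note shows. Statements on the series, on what has been measured and on what is new or still open speak of the compounds shown alone.

Compound 1, `Cc1ccc(NC(=S)NC(=O)c2ccc(OCc3ccc(C(F)(F)F)cc3)cc2)cc1-c1nc2ccccc2[nH]1`, is the reference point of this series. In a functional assay on MNK45 cells (Homo sapiens) for inhibition, read by MTT assay, with a stated time of 48 h (on this read-out lower numbers stand for stronger inhibition and higher numbers for weaker inhibition), compound 1 gives 10200 nM, the higher of the two numbers shown; its nearest neighbour is compound 2, `Cc1ccc(NC(=S)NC(=O)c2ccc(OCc3cccc(C(F)(F)F)c3)cc2)cc1-c1nc2ccccc2[nH]1`, which in this assay gives 6050 nM, and the move a 1.7-fold lower number from compound 1 to compound 2 (0.23 log units; within the scatter). Compound 3, `Cc1ccc(NC(=S)NC(=O)c2ccc(OCc3cccc(Cl)c3Cl)cc2)cc1-c1nc2ccccc2[nH]1`, reaches only a limit in this assay, > 100000 nM, as described by the limit of > 100000 nM in this assay, at which 1 of the 3 values shown sits. From compound 3 the steps run an at least 9.8-fold higher number from compound 1 to compound 3 (0.99 log units; beyond the scatter) and an at least 16-fold higher number from compound 2 to compound 3 (1.21 log units; beyond the scatter).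

The change to compound 4, `Cc1ccc(NC(=S)NC(=O)c2ccc(OCc3cccc(F)c3)cc2)cc1-c1nc2ccccc2[nH]1`, is 3-fluorophenyl in place of 4-(trifluoromethyl)phenyl on a saturated chain carbon bound to an oxygen on an aromatic ring. Within the data shown here, no measured step tests a fluoro group directly. The step from compound 1 to compound 2 shows that moving the trifluoromethyl to the 3-position costs nothing beyond the scatter, whereas the steps to compound 3 show that a different benzyl pattern can erase activity. Compound 4 is therefore expected to stay close to compound 1, with some risk of weakening, giving a 1.5-fold higher number from compound 1 to compound 4 (0.17 log units; within the scatter). In this assay compound 4 is estimated at 15000 nM, within 5000 nM to 60000 nM.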

Compound 4, half-maximal inhibitory concentration: 86800 nM
Estimate against measurement, compound 4: 5.8-fold (0.76 log units) below; the whole stated range lies below it.
By their numbers in this assay, from the lowest: compounds 2 and 1 (each within the scatter of the next); then compound 4. At a limit, above all of these: compound 3.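

Where the earlier compounds showed that trifluoromethyl could change place on the benzyl group with no shift beyond the scatter (a 1.7-fold lower number from compound 1 to compound 2 (0.23 log units; within the scatter)), fluoro in place of trifluoromethyl on an aromatic carbon does matter in this assay (a 14-fold higher number from compound 2 to compound 4 (1.16 log units; beyond the scatter)). The 3-fluorophenyl group also compares poorly with 4-(trifluoromethyl)phenyl on the same saturated chain carbon (an 8.5-fold higher number from compound 1 to compound 4 (0.93 log units; beyond the scatter)), so among the compounds with a measured number, those with trifluoromethyl give the lower numbers. Compound 3 stands at a limit, and the step that remains is only a floor within the scatter (an at least 1.1-fold lower number from compound 3 to compound 4 (0.06 log units; that floor lies within the scatter)), so it cannot be read further: the limit of > 100000 nM in this assay, at which 1 of the 4 values shown sits.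

Open, from the compounds shown here alone, is whether a single chlorine, a methoxy group or a nitrile at this place would behave like trifluoromethyl or like fluoro. Also open, going by these compounds, is how a plain phenyl group would read here.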